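A few compounds are considered here, and "the series" means these few. Any claim that something is new, unique, unknown or untested is made for them only; others in the source may bear on it.

Of the compounds shown here, two on a shared core have been measured in a functional assay on A549 cells (Homo sapiens) for cytotoxicity, with a stated time of 48 h; on this read-out higher numbers stand for weaker inhibition and lower numbers for stronger inhibition. Compound 1 `Cc1ccc2oc(/C=C/[S+](C)[O-])cc(=O)c2c1` gives 1700 nM, and compound 2 `CC(C)C(=O)Oc1ccc2oc(/C=C/[S+](C)[O-])cc(=O)c2c1`, which carries (isopropylcarbonyl)oxy in place of methyl on an aromatic carbon, gives 2400 nM. Within the data shown here, the one measured step is a 1.4-fold higher number from compound 1 to compound 2 (0.15 log units; within the scatter), so these two values stand within the scatter of each other and neither ranks ahead. Among the measured compounds shown here, compound 2 therefore holds no separate place on the numbers so far.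

Compound 3 `CC(C)Oc1ccc2oc(/C=C/[S+](C)[O-])cc(=O)c2c1` has not yet been measured. It differs from compound 2 by isopropyl in place of isopropylcarbonyl on an oxygen on an aromatic ring. For the measured compounds named here, no measured pair shows this exchange directly, and a single earlier step at this place is thin evidence. Going by the values given here, with a 1.4-fold higher number from compound 1 to compound 2 (0.15 log units; within the scatter) as the only guide, no step beyond the scatter is expected in this assay, and no direction can be favoured with any confidence. The expected change is a 1.2-fold lower number from compound 2 to compound 3 (0.08 log units; within the scatter). For compound 3 the estimate is 2000 nM, with an expected range from 800 nM to 5000 nM.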

Compound 3, half-maximal inhibitory concentration: 1500 nM
Beside the measured number, compound 3's estimate is 1.3-fold (0.12 log units) above it, within the range that was stated.
By their numbers in this assay, from the lowest: compounds 3, 1 and 2 (each within the scatter of the next).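

In this assay, isopropyl in place of isopropylcarbonyl on an oxygen on an aromatic ring gives a 1.6-fold lower number from compound 2 to compound 3 (0.20 log units; within the scatter), so the isopropoxy and (isopropylcarbonyl)oxy forms cannot be told apart on these numbers, whether or not the carbonyl is present. Isopropoxy in place of methyl on an aromatic carbon gives a 1.1-fold lower number from compound 1 to compound 3 (0.05 log units; within the scatter), which means that methyl, (isopropylcarbonyl)oxy and isopropoxy at this place now all stand within the scatter of one another, a wider set of groups than the single earlier step could show. No independent evidence bears on this result.

The three compounds leave open whether any group at this place can move the number beyond the scatter, for instance an amine, a carboxylic acid or a longer chain on the oxygen. They also leave open whether changes elsewhere on the shared core would separate compounds that this position does not, and whether the same even picture would hold in any other read-out.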